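The source may hold more compounds than are shown below. What is called first, only, known or untested is meant among the compounds shown, and "the series" means these compounds.

In an ADME assay on LLC-MK2 cells (Macaca mulatta) for cytotoxicity, read by spectrophotometry and crystal violet staining, with a stated time of 4 days (a lower number here means that less compound is tolerated, a higher number that more compound is tolerated), compound 1 (`CC(C)n1ncc2c(C(=O)Nc3ccccc3F)cc(-c3cccs3)nc21`) gives 50000 nM, compound 2 (`CC(C)n1ncc2c(C(=O)Nc3cc(C(N)=O)ccc3F)cc(-c3cccs3)nc21`) gives 25000 nM and compound 3 (`CC(C)n1ncc2c(C(=O)Nc3cccc(F)c3F)cc(-c3cccs3)nc21`) gives 75000 nM. Compound 3 cannot be separated from compound 1 on these numbers, and it lies beyond the scatter only against compound 2. The two steps read a 1.5-fold higher number from compound 1 to compound 3 (0.18 log units; within the scatter) and a 3.0-fold higher number from compound 2 to compound 3 (0.48 log units; beyond the scatter).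

Compound 4 (`CC(C)n1ncc2c(C(=O)Nc3ccccn3)cc(-c3cccs3)nc21`) carries pyridin-2-yl in place of 2,3-difluorophenyl on an amide-type nitrogen. For the measured compounds named here, no measured step makes this exchange of rings, so the evidence is indirect. The nearest guides are the other changes to the group on that nitrogen, which stay small: a 2.0-fold lower number from compound 1 to compound 2 (0.30 log units; within the scatter) sits within the scatter, and the largest of the three is the modest step from compound 2 described above. A step beyond the scatter is therefore not expected in this assay, with a slight drift to a lower number as the only tentative direction. The expected step is a 1.5-fold lower number from compound 3 to compound 4 (0.18 log units; within the scatter). The estimate for compound 4 is 50000 nM, with an expected range of 20000 nM to 100000 nM.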

Compound 4, half-maximal cytotoxic concentration: > 200000 nM
Compound 4: a limit, no number; the forecaster's own chance of this, stated with the estimate: 20%; middle value at least 4.0-fold (0.60 log units) from the limit.
By their numbers in this assay, from the lowest: compounds 2, 1 and 3 (each within the scatter of the next, the first and the last beyond it). At a limit, above all of these: compound 4.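

In this assay, the reading for compound 4 is a limit of the assay and not a number: the limit of > 200000 nM in this assay, at which 1 of the 4 values shown sits. Pyridin-2-yl on the amide-type nitrogen separates this compound from all the phenyl-bearing analogues shown, giving an at least 2.6-fold higher number from compound 3 to compound 4 (0.42 log units; beyond the scatter), an at least 4.0-fold higher number from compound 1 to compound 4 (0.60 log units; beyond the scatter) and an at least 8.0-fold higher number from compound 2 to compound 4 (0.90 log units; beyond the scatter). Among the compounds shown, the fluoro and carbamoyl changes on the phenyl ring gave steps within the scatter or modest ones, whereas this exchange of the whole ring is the first change at this position to stand clear of every other compound.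

From the compounds shown here alone, the true size of these steps stays open, since only a limit bounds them. Also open, going by these compounds, is how an amine, a carboxylic acid or a fluoro group on the pyridin-2-yl ring would read in this assay.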